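The source may report more compounds than this note shows. Statements on the series, on what has been measured and on what is new or still open speak of the compounds shown alone.

The series shares one core; compound 1 `COc1cc(-c2nn(-c3cccc(NC(=O)c4cccc(C(F)(F)F)c4)c3)cc2-c2ccncc2)ccc1Cl`, compound 2 `COc1cc(-c2nn(-c3cccc(NC(=O)Nc4ccc(Cl)c(Cl)c4)c3)cc2-c2ccncc2)ccc1Cl` and compound 3 `COc1cc(-c2nn(-c3cccc(NC(=O)c4ccc(Cl)c(C(F)(F)F)c4)c3)cc2-c2ccncc2)ccc1Cl` differ only in the group carried on the carbonyl carbon. In a functional assay on HT-29 cells (Homo sapiens) for inhibition, read by sulforhodamine B assay, with a stated time of 48 h (a higher number here means a weaker inhibitor of growth, a lower number a stronger inhibitor of growth), compound 1 gives 1390 nM, compound 2 gives 1240 nM and compound 3 gives 3380 nM. Compound 3 stands highest of the three numbers: the change a 2.4-fold higher number from compound 1 to compound 3 (0.39 log units; beyond the scatter) and the change a 2.7-fold higher number from compound 2 to compound 3 (0.44 log units; beyond the scatter) both lie beyond the scatter, whereas a 1.1-fold lower number from compound 1 to compound 2 (0.05 log units; within the scatter) lies within it.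

Compound 4 `COc1cc(-c2nn(-c3cccc(NC(=O)Nc4ccc(Cl)c(C(F)(F)F)c4)c3)cc2-c2ccncc2)ccc1Cl` has not yet been measured in this assay. It differs from compound 3 by (4-chloro-3-(trifluoromethyl)phenyl)amino in place of 4-chloro-3-(trifluoromethyl)phenyl on a carbonyl carbon. Within the data shown here, the one measured step that bears on this exchange, an aryl group replaced by an arylamino group on the carbonyl carbon, is a 1.1-fold lower number from compound 1 to compound 2 (0.05 log units; within the scatter), which stayed within the scatter even though the aryl group itself also changed there. Here the aryl group is kept, so the expected change in this assay is a 1.3-fold lower number from compound 3 to compound 4 (0.11 log units; within the scatter), not beyond the scatter. Compound 4 is therefore expected to give 2600 nM, with a range from 1200 nM to 5600 nM.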

Compound 4, concentration for 50% growth inhibition: 1190 nM
Compound 4: the middle estimate sits 2.2-fold (0.34 log units) above what was measured, and the stated range ends above it.
By their numbers in this assay, from the lowest: compounds 4, 2 and 1 (each within the scatter of the next); then compound 3.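

With the 4-chloro-3-(trifluoromethyl)phenyl group held constant, placing the amino link on the carbonyl carbon gives a 2.8-fold lower number from compound 3 to compound 4 (0.45 log units; beyond the scatter) in this assay and so isolates an exchange that the earlier aryl-to-arylamino step had mixed with a change in the aryl group. The arylamino compound 4 does not stand apart from its neighbours, as a 1.0-fold lower number from compound 2 to compound 4 (0.02 log units; within the scatter) and a 1.2-fold lower number from compound 1 to compound 4 (0.07 log units; within the scatter) both show, so trifluoromethyl and chloro on the arylamino ring cannot be told apart here. Among these four compounds, only compound 3 stands apart, and nothing available accounts for this.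

Going by these compounds, it remains open whether an oxygen or a methylene in place of the amino nitrogen would track compound 4 or compound 3. Also open, on these data alone, is whether a morpholine or piperazine on the aryl ring would move the number beyond the level shared by compounds 1, 2 and 4.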